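Replacing phenyl by furan-2-yl at the chain carbon

The source may hold more compounds than are shown below. What is called first, only, known or untested is meant among the compounds shown, and "the series" means these compounds.

Compound 1 `COC(/C=C/c1ccccc1)=C1\C(=O)C=C(C)C1=O` is the reference of the series. In an ADME assay on LLC-PK1 cells (Sus scrofa) for cytotoxicity, read by neutral red uptake (on this read-out lower numbers stand for stronger inhibition and higher numbers for weaker inhibition), compound 1 gives 3.4 ug/mL. Compound 2 `COC(/C=C/c1ccc(Cl)cc1)=C1\C(=O)C=C(C)C1=O` gives 3.1 ug/mL in this assay, and the step of a 1.1-fold lower number from compound 1 to compound 2 (0.04 log units; within the scatter) stays within the scatter. Within the data shown here, compound 1 therefore stands at the highest of the two numbers so far, with compound 2 nearest, the two not distinguishable.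

Compound 3 `COC(/C=C/c1ccco1)=C1\C(=O)C=C(C)C1=O` has not yet been measured. It differs from compound 1 by furan-2-yl in place of phenyl on a double-bonded chain carbon bound to a double-bonded chain carbon. Among the measured compounds shown here, the one measured step concerns a chloro on the phenyl that itself leaves here, so it does not speak to the exchange of one aromatic ring for another and was within the scatter anyway. For the measured compounds named here, no measured step bears on this change. The expectation is therefore no step beyond the scatter, a 1.0-fold higher number from compound 1 to compound 3 (0.01 log units; within the scatter) in this assay. Compound 3 is estimated at 3.5 ug/mL, with a range from 1.7 ug/mL to 7 ug/mL.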

Compound 3, half-maximal inhibitory concentration: 3.3 ug/mL
Compound 3: the middle estimate sits 1.1-fold (0.03 log units) above what was measured; low and high end bracket the measured number.
By their numbers in this assay, from the lowest: compounds 2, 3 and 1 (each within the scatter of the next).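

At the double-bonded chain carbon bound to a double-bonded chain carbon, the exchange of furan-2-yl for phenyl amounts in this assay to a 1.0-fold lower number from compound 1 to compound 3 (0.01 log units; within the scatter) and so cannot be told apart from no change. The earlier chloro step kept the phenyl, whereas here the aromatic ring itself is replaced: a five-membered aromatic ring with 1 hetero atom and 1 hydrogen-bond acceptor stands in for a six-membered aromatic ring of carbon only, with no step beyond the scatter. No measured evidence offers an explanation for this result.

Still open, going by these compounds, is whether a group of another kind at this place, such as cyclohexyl or a phenyl carrying a carboxylic acid, would separate from compound 1 in this assay. The compounds shown include no change at this place that gives a step beyond the scatter, so what this position would not accept remains unknown.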